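The source may report more compounds than this note shows. Statements on the series, on what has been measured and on what is new or still open speak of the compounds shown alone.

Compound 1 `CC(=O)Oc1ccc(/C=C/C(=O)O)cc1OC(C)=O`: in an assay on isolated protein for inhibition of Polyunsaturated fatty acid 5-lipoxygenase (Homo sapiens), read by HPLC, with a stated time of 15 min (a higher number here means a weaker inhibitor, a lower number a stronger inhibitor), compound 1 gives > 10000 nM, which is a limit of the assay and not a number.
Compound 2 `C#CCCOC(=O)/C=C/c1ccc(OC(C)=O)c(OC(C)=O)c1`: in this assay compound 2 gives > 10000 nM, again a limit of the assay and not a number.

Compound 2 therefore stands at the edge of what this assay can report; (the limit of > 10000 nM in this assay, at which 2 of the 2 values shown sit), so no measured number places it anywhere more exactly. Going by the values given here, the single step between measured compounds, a step that the two limits leave unreadable from compound 1 to compound 2, cannot be read because of the limit of > 10000 nM in this assay, at which 2 of the 2 values shown sit.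

Compound 3 `C#CCCCCOC(=O)/C=C/c1ccc(OC(C)=O)c(OC(C)=O)c1` differs from compound 2 in one place: but-3-yn-1-yl in place of ethynyl on a saturated chain carbon, two bonds along the chain from an oxygen next to a carbonyl group. Among the compounds with values here, no readable measured step bears on this change, since the one step available is unreadable; the change also lies on the same saturated chain where that unreadable step sat, and it only lengthens the chain. With nothing pointing either way, and compound 2 already at a limit, the expectation is that compound 3 stays at the limit as well. Compound 3 is thus expected to give about 15000 nM, with a range from 7000 nM to 50000 nM, most likely reported only as a limit. This estimate means an expected step that the limit leaves unreadable from compound 2 to compound 3, which says little, as it starts from a limit.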

Compound 3, half-maximal inhibitory concentration: > 10000 nM
Compound 3: a limit, no number (the forecaster's own chance of this, stated with the estimate: 85%); the middle value does not contradict the limit.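

Going by these compounds alone, no step among compound 1, compound 2 and compound 3 can be read, because all three stand at the same limit: the limit of > 10000 nM in this assay, at which 3 of the 3 values shown sit. The compounds shown leave open how strongly any of them inhibits the enzyme, and whether putting but-3-yn-1-yl or hex-5-yn-1-yl in place of hydrogen changes that inhibition at all.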